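The source may hold more compounds than are shown below. What is called first, only, known or untested is meant among the compounds shown, and "the series" means these compounds.

Compound 1 `CCCCCOC(=O)C(O)Cn1cnc2c(N)ncnc21` gives 200 ug/mL in a functional assay on PRK cells (Oryctolagus cuniculus) for cytotoxicity; a lower number here means that less compound is tolerated, a higher number that more compound is tolerated. Compound 2 `CC(C)COC(=O)C(O)Cn1cnc2c(N)ncnc21` carries an isopropyl in place of the butyl, and in this assay compound 2 reaches > 400 ug/mL, which is a limit of the assay rather than a measured number. Among the compounds with values here, the only measured step, an at least 2.0-fold higher number from compound 1 to compound 2 (0.30 log units; that floor lies within the scatter), therefore gives a floor and not a size. Compound 3 `CC(C)(C)OC(=O)C(O)Cn1cnc2c(N)ncnc21` is reached from compound 2 by tert-butyl in place of isobutyl on an oxygen next to a carbonyl group. Within the data shown here, no measured step involves a tert-butyl, so no move beyond the scatter is expected, and the step from compound 2 to compound 3 is estimated as a number no higher from compound 2 to compound 3 (the limit leaves the size open). Compound 3 is thus expected near 400 ug/mL, between 200 ug/mL and 800 ug/mL.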

Compound 3, minimum cytotoxic concentration: > 400 ug/mL
Compound 3 gave a limit, no number; the forecaster's own chance of this, stated with the estimate: 60%; the middle value sits exactly at the limit.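

In this assay compound 3 gives > 400 ug/mL, which is a limit of the assay and not a number. Swapping pentyl for tert-butyl gives an at least 2.0-fold higher number from compound 1 to compound 3 (0.30 log units; that floor lies within the scatter), so tert-butyl on this oxygen, like isobutyl, yields only a floor and not a size. The change from isobutyl to tert-butyl cannot be read, because both compounds stand at one ceiling: the limit of > 400 ug/mL in this assay, at which 2 of the 3 values shown sit.

Going by these compounds, how far the true values of compound 2 and compound 3 lie beyond that limit stays open. So does the outcome with a longer chain, such as hexyl, or a benzyl group on this oxygen.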